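The source may hold more compounds than are shown below. What is called first, only, known or untested is meant among the compounds shown, and "the series" means these compounds.

In a functional assay on the whole organism (strain Sprague-Dawley) for inhibition, with Rattus norvegicus as the target, with a stated time of 10 min (on this read-out lower numbers stand for an effect already at smaller amounts and higher numbers for an effect only at larger amounts of compound), compound 1 (`CCOc1ccc(OC)cc1-c1ncc(C(=O)O)c(=O)[nH]1`) gives 0.2 mg/kg, and compound 2 (`CCOC(=O)c1cnc(-c2cc(OC)ccc2OCC)[nH]c1=O`) gives 0.3 mg/kg. Among the measured compounds shown here, the only measured step is a 1.5-fold higher number from compound 1 to compound 2 (0.18 log units; within the scatter), so compound 2 cannot be told apart from compound 1 on these numbers. Compound 3 (`CCOC(=O)c1cnc(-c2cc(S(N)(=O)=O)ccc2OCC)[nH]c1=O`) keeps everything in compound 2 except for one swap, sulfamoyl in place of methoxy on an aromatic carbon, para to an ethoxy group: sulfamoyl in place of methoxy on an aromatic carbon. For the measured compounds named here, the one measured step lies at a different place in the molecule, so it gives little guidance here, and no measured pair tests a change at this aromatic carbon. The expected change is a 2.0-fold higher number from compound 2 to compound 3 (0.30 log units; within the scatter), a cautious guess whose direction the data cannot settle. For compound 3 the estimated value is 0.6 mg/kg, with an expected range of 0.1 mg/kg to 4 mg/kg.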

Compound 3, dose for 50% inhibition: 50 mg/kg
Compound 3: the middle estimate sits 83-fold (1.92 log units) below what was measured; the whole stated range lies below it.
By their numbers in this assay, from the lowest: compounds 1 and 2 (each within the scatter of the next); then compound 3.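

In this assay, among the compounds shown here, the aromatic carbon para to an ethoxy group proves sensitive to change: sulfamoyl in place of methoxy gives a 170-fold higher number from compound 2 to compound 3 (2.22 log units; beyond the scatter), whereas the only earlier step, at a different place in the molecule, stayed within the scatter. Sulfamoyl brings more heavy atoms than methoxy and adds a hydrogen-bond donor, but this single swap cannot show which of these differences matters, if either does. Nothing measured here explains why the number rises so far.

As far as these compounds go, it remains open whether any replacement of methoxy at this carbon has a similar effect, or whether this is specific to sulfamoyl; a methyl group or an amine there would help to separate the two. From the compounds shown here alone, it is also open whether sulfamoyl has as large an effect when the ethyl ester is replaced by the carboxylic acid of compound 1.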